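A few compounds are considered here, and "the series" means these few. Any claim that something is new, unique, unknown or untested is made for them only; others in the source may bear on it.

In a functional assay on CCRF-CEM cells (Homo sapiens) for antiproliferative activity (a lower number here means a stronger inhibitor, a higher number a weaker inhibitor), compound 1 (`O=C1NC(O)C(F)=CN1[C@H]1C=C[C@@H](CO)O1`) gives 9100 nM and compound 2 (`Nc1nc(=O)n([C@H]2C=C[C@@H](CO)O2)cc1Br`) gives 42500 nM as the higher of the two numbers, a gap beyond the scatter. Compound 3 (`Nc1nc(=O)n([C@H]2C=C[C@@H](CO)O2)cc1I`) is still unmeasured and differs from compound 2 in one place (iodo in place of bromo on an aromatic carbon), with iodo in place of bromo on an aromatic carbon. Among the compounds with values here, no measured pair shows this exchange, so no step beyond the scatter is expected in this assay for this change. The expected step (a 1.1-fold lower number from compound 2 to compound 3 (0.05 log units; within the scatter)) is small and has no firm direction. For compound 3 the estimated value is 38000 nM with 15000 nM to 95000 nM as the expected range of results.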

Compound 3, half-maximal inhibitory concentration: 107000 nM
For compound 3 the middle estimate is 2.8-fold (0.45 log units) below the measured one; measured number outside the range, above it.
By their numbers in this assay, from the lowest: compound 1; then compound 2; then compound 3.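

In this assay, exchanging bromo for iodo on the aromatic carbon ortho to an amino group gives a 2.5-fold higher number from compound 2 to compound 3 (0.40 log units; beyond the scatter). Within the data shown here, this single pair gives the first direct reading at this position, showing that inhibition here weakens with this one-atom exchange. No measurement shown accounts for the step.

As far as these compounds go, a single pair gives one step and no trend, so how chloro, a methyl group or a hydrogen at this position would compare remains open. From the compounds shown here alone, whether the same exchange would act alike with another group in place of the amino group also remains open.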